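The compounds below may be only part of what the source reports. "The series", "measured", "known", "first", "only" and "open" are said of these compounds alone.

In a functional assay on K562 cells (Homo sapiens) for antiproliferative activity, read by MTT assay, with a stated time of 48 h (on this read-out higher numbers stand for weaker inhibition and lower numbers for stronger inhibition), three compounds with a shared core have been tested. Compound 1 (`Cn1c(N)c(-c2nc3ccccc3[nH]2)c2nc(C#N)c(C#N)nc21`) gives > 50000 nM as a limit of the assay. Compound 2 (`CN1CCN(CCn2c(N)c(-c3nc4ccccc4[nH]3)c3nc(C#N)c(C#N)nc32)CC1`) gives 6550 nM as a true number. Compound 3 (`CCCn1c(N)c(-c2nc3ccccc3[nH]2)c2nc(C#N)c(C#N)nc21`) gives > 50000 nM as a limit of the assay, so it has no number of its own. The unmeasured compound 4 (`N#Cc1nc2c(-c3nc4ccccc4[nH]3)c(N)n(CCO)c2nc1C#N`) differs from compound 3 by hydroxy in place of methyl on a saturated chain carbon, two bonds along the chain from an aromatic nitrogen in one change: hydroxy in place of methyl on a saturated chain carbon, two bonds along the chain from an aromatic nitrogen.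

The closest measured change, ethyl in place of hydrogen, gives a step that the two limits leave unreadable from compound 1 to compound 3 and so offers no size. Readable movement comes only with the 4-methylpiperazin-1-yl group, as an at least 7.6-fold lower number from compound 1 to compound 2 (0.88 log units; beyond the scatter) and as an at least 7.6-fold higher number from compound 2 to compound 3 (0.88 log units; beyond the scatter) in the opposite direction. Compound 4 lacks that group, and hydroxy has not been tested here. Compound 1 and compound 3, both without that group, sit at the limit of > 50000 nM in this assay, at which 2 of the 3 values shown sit, and this points to little gain. The expected change is a number no higher from compound 3 to compound 4 (the limit leaves the size open) with no clear movement beyond the scatter. The estimated value for compound 4 is 50000 nM with an expected range from 20000 nM to 100000 nM in this assay and a reading at the limit is likely.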

Compound 4, half-maximal inhibitory concentration: > 50000 nM
Compound 4: a limit, no number (the forecaster's own chance of this, stated with the estimate: 60%); the middle value sits exactly at the limit.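

In this assay compound 4 gives > 50000 nM, which is a limit of the assay and not a number. Hydroxy on this saturated chain carbon, two bonds along the chain from an aromatic nitrogen, therefore gives no readable value, just as methyl at the same place gave none, and the steps from compound 3 and from compound 1 to compound 4 cannot be read. Putting hydroxy in place of 4-methylpiperazin-1-yl at that place gives an at least 7.6-fold higher number from compound 2 to compound 4 (0.88 log units; beyond the scatter), so a true number in this set still comes only with the 4-methylpiperazin-1-yl group, while the limit remains the common outcome: the limit of > 50000 nM in this assay, at which 3 of the 4 values shown sit.

The compounds shown leave open whether the activity of compound 2 needs the whole 4-methylpiperazin-1-yl group or would also appear with a simpler amine, such as dimethylamino, or with a morpholin-4-yl group on the same chain. They also leave open how a carboxylic acid at this place would read, and how compound 1, compound 3 and compound 4 rank among themselves, since none of the three has a number of its own.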